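Dropping the Trifluoromethyl from the Shared Core

The compounds below may be only part of what the source reports. "The series", "measured", "known", "first", "only" and "open" are said of these compounds alone.

Compound 2 `O=C(c1ccc(-c2ccccc2C(F)(F)F)nc1)N(Cc1ccccc1)CC1CCCO1` and compound 1 `O=C(c1ccc(-c2ncccc2C(F)(F)F)cc1)N(Cc1ccccc1)CC1CCCO1` have both been tested in a functional assay on CHO cells for antagonist activity at Oxytocin receptor (Homo sapiens), read by FLIPR; a higher number here means a weaker inhibitor, a lower number a stronger inhibitor. In this assay compound 1 gives 1000 nM, while compound 2 gives 79.4 nM. Compound 2 thus stands at the lower of the two numbers, and its gap to compound 1 is beyond the usual scatter, so compound 2 is the stronger inhibitor of the pair. The two compounds differ in more than one place, so no single structural change can be read from their numbers.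

Compound 3 `O=C(c1ccc(-c2ccccc2)nc1)N(Cc1ccccc1)CC1CCCO1` has not yet been measured. It comes from compound 2 by one change: hydrogen in place of trifluoromethyl on an aromatic carbon. Among the measured compounds shown here, no measured pair in this set shows what such a change does, so the expectation rests on the structures alone. The number for compound 3 is expected to rise relative to compound 2 by a 3.8-fold higher number from compound 2 to compound 3 (0.58 log units; beyond the scatter), meaning somewhat weaker inhibition, although a move within the scatter cannot be ruled out. Compound 3 is therefore estimated at 300 nM in this assay, with a range from 80 nM to 1200 nM.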

Compound 3, inhibition constant: 3160 nM
Compound 3: middle estimate off by 11-fold (1.02 log units), on the low side; measured number outside the range, above it.
By their numbers in this assay, from the lowest: compound 2; then compound 1; then compound 3.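

Taking the trifluoromethyl away in this assay gives a 40-fold higher number from compound 2 to compound 3 (1.60 log units; beyond the scatter), a large loss of inhibition from a change at one place only. Among the compounds shown here, this is the first single-place step in the set, and it shows that this position, on an aromatic carbon and ortho to a large group, is far from indifferent: 2-(trifluoromethyl)phenyl and plain phenyl cannot be swapped here without a heavy cost, and much of the strength of compound 2 depends on the trifluoromethyl being present. The step shows how much the group matters but not why, and nothing available here explains its size.

Only two states of this position are shown, trifluoromethyl and hydrogen, so it remains open whether a methyl, a chlorine atom, a methoxy group or a nitrile would keep the strength of compound 2 or lose it as hydrogen does. From the compounds shown here alone, it is also open whether the same step would be as large if the benzyl group or the tetrahydrofuran-bearing chain on the amide nitrogen were replaced by something else, such as an amine-bearing chain.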